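The source may hold more compounds than are shown below. What is called first, only, known or untested is meant among the compounds shown, and "the series" means these compounds.

Working notes on the series. In a functional assay on A549 cells (Homo sapiens) for inhibition, read by CCK-8 assay, with a stated time of 48 h (on this read-out higher numbers stand for weaker inhibition and lower numbers for stronger inhibition), three compounds sharing one core have been measured. Compound 1 `COc1cc(-c2ccnc3cc(-c4cn(C)c5ccccc45)nn23)cc(OC)c1OC` gives 1340 nM, compound 2 `COc1cc(-c2ccnc3cc(-c4cccc(C)c4)nn23)cc(OC)c1OC` gives 5730 nM and compound 3 `COc1cc(-c2ccnc3cc(-c4ccc5cnn(C)c5c4)nn23)cc(OC)c1OC` gives 233 nM. Compound 3 has the lowest number of the three, and its steps to both others lie beyond the scatter.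

Next is compound 4 `COc1cc(-c2ccnc3cc(-c4ccc(C(C)(C)C)cc4)nn23)cc(OC)c1OC`, with 4-(tert-butyl)phenyl in place of 1-methyl-1H-indazol-6-yl on an aromatic carbon.

The most relevant measurement is the change between 3-methylphenyl and 1-methyl-1H-indazol-6-yl, a 25-fold lower number from compound 2 to compound 3 (1.39 log units; beyond the scatter). Compound 4 reverses that kind of change, again leaving a phenyl group at this carbon. The other two steps are smaller: a 5.8-fold lower number from compound 1 to compound 3 (0.76 log units; beyond the scatter) and a 4.3-fold higher number from compound 1 to compound 2 (0.63 log units; beyond the scatter). Within the data shown here, neither involves a 4-(tert-butyl)phenyl group, and no measured compound carries one, so the reading rests mainly on compound 2 and the range stays wide.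

A large step to a higher number, meaning weaker inhibition, is expected in this assay. The expected change is a 17-fold higher number from compound 3 to compound 4 (1.23 log units; beyond the scatter). The estimated value for compound 4 is 4000 nM, with an expected range of 1200 nM to 13000 nM.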

Compound 4, half-maximal inhibitory concentration: > 10000 nM
Compound 4: a limit, no number (the forecaster's own chance of this, stated with the estimate: 5%); at least 2.5-fold (0.39 log units) between middle value and limit.
By their numbers in this assay, from the lowest: compound 3; then compound 1; then compound 2. At a limit, above all of these: compound 4.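

In this assay compound 4 reads as a limit of the assay, not as a number: the limit of > 10000 nM in this assay, at which 1 of the 4 values shown sits. Even so, its floors show that 4-(tert-butyl)phenyl on this aromatic carbon costs far more than the spread among the earlier groups suggested, with an at least 42-fold higher number from compound 3 to compound 4 (1.63 log units; beyond the scatter) and an at least 7.4-fold higher number from compound 1 to compound 4 (0.87 log units; beyond the scatter), and the step from 1-methyl-1H-indazol-6-yl is a swap between groups of the same heavy-atom count, so that count alone does not track the read-out here. Against the other phenyl group the floor settles nothing, with an at least 1.7-fold higher number from compound 2 to compound 4 (0.24 log units; that floor lies within the scatter), so compound 2 and compound 4 cannot be put in a firm order, although both phenyl compounds lie beyond the scatter from compound 3.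

Left open is whether the ring nitrogens of 1-methyl-1H-indazol-6-yl, which bring hydrogen-bond acceptors absent from 4-(tert-butyl)phenyl, or the fused ring itself sets the gap. Going by these compounds, a simple aminophenyl or pyridyl group at this carbon would bear on that question, and the true value of compound 4 remains unknown behind its limit.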